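This account rests on a few compounds, and the source may have more. Where it says the series, first, only, none or still open, it means among the compounds named here.

Compound 2 `O=C(NCCCOc1ccc2nc(O)ccc2c1)N(C1CC1)[C@H]1CC[C@H](O)CC1` gives 7% in a functional assay on the whole organism for inhibition, with Rattus norvegicus as the target, at a dose of 30 mg/kg by the oral route (a higher number here means more inhibition at the dose given (going by the name of the read-out), a lower number less inhibition), the higher of the two numbers seen so far, while compound 1 `O=C(NCCCOc1ccc2nc(O)ccc2c1)N(C1CC1)[C@@H]1CCC[C@@H](O)C1` gives 0%, and the step of a number 7 percentage points higher from compound 1 to compound 2 (within the scatter) lies within the scatter. Compound 3 `O=C(NCCCOc1ccc2nc(O)ccc2c1)N(C1CC1)[C@H]1CCCC[C@H]1O` carries the change (2-hydroxycyclohexyl in place of 4-hydroxycyclohexyl on an amide-type nitrogen). Among the measured compounds shown here, the only measured step, a number 7 percentage points higher from compound 1 to compound 2 (within the scatter), likewise exchanged one hydroxycyclohexyl group for another and stayed within the scatter, so no step beyond the scatter is expected here either. The expected step of a number 2 percentage points lower from compound 2 to compound 3 (within the scatter) is small. Compound 3 is therefore estimated at 5%, with a range from 0% to 20%.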

Compound 3, a percentage reported as inhibition, in the whole organism at one dose (the size of the read-out at that dose, not a potency): 19%
Estimate against measurement, compound 3: 14 percentage points below, within the range that was stated.
By their numbers in this assay, from the lowest: compounds 1 and 2 (each within the scatter of the next); then compound 3.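

Compound 3 shows that the choice of hydroxycyclohexyl group on this amide-type nitrogen can matter in this assay: 2-hydroxycyclohexyl in place of 4-hydroxycyclohexyl gives a number 12 percentage points higher from compound 2 to compound 3 (beyond the scatter), and 2-hydroxycyclohexyl in place of 3-hydroxycyclohexyl gives a number 19 percentage points higher from compound 1 to compound 3 (beyond the scatter). Among the compounds shown here, the earlier exchange of hydroxycyclohexyl groups had stayed within the scatter, so these are the first steps at this position to pass beyond it, though both remain modest. Nothing available explains why the 2-hydroxycyclohexyl group stands apart.

Going by these compounds, it remains open how the other stereoisomers of 2-hydroxycyclohexyl would compare. On these data alone, it is also open whether 2-aminocyclohexyl or 2-methoxycyclohexyl on this nitrogen would match compound 3.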